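The source may hold more compounds than are shown below. What is called first, only, known or untested is meant among the compounds shown, and "the series" means these compounds.

Of the compounds shown here, three carrying the same imide core have been tested in a functional assay on the whole organism (strain CD1) with Mus musculus as the target, in the maximal electroshock model, with a stated time of 0.5 h; on this read-out higher numbers stand for an effect only at larger amounts of compound and lower numbers for an effect already at smaller amounts. Compound 1 `CC1CC(=O)N(CC(=O)N2CCN(c3ccc(Cl)cc3)CC2)C1=O` gives 100 mg/kg. Compound 2 `CCC1(C)CC(=O)N(CC(=O)N2CCN(c3ccccc3Cl)CC2)C1=O` gives 100 mg/kg. Compound 3 `CC1CC(=O)N(CC(=O)N2CCN(c3ccccc3Cl)CC2)C1=O` gives 300 mg/kg. Compound 2 thus stands level with compound 1 at the digits shown, the two lowest numbers of the three, while the step of a 3.0-fold higher number from compound 2 to compound 3 (0.48 log units; beyond the scatter) lies beyond the scatter.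

Compound 4 `CCC1(C)CC(=O)N(CC(=O)N2CCN(c3ccc(F)cc3)CC2)C1=O` has not yet been measured. Its difference from compound 2 is 4-fluorophenyl in place of 2-chlorophenyl on an amine nitrogen in a ring. Going by the values given here, no measured step swaps chlorine for fluorine, so that part of the change is uncharted. Among the compounds with values here, the one step that touches the aromatic group on this ring nitrogen is a 3.0-fold higher number from compound 1 to compound 3 (0.48 log units; beyond the scatter), which moved the substituent away from the 4-position and raised the number; compound 4 moves it back to the 4-position, and compound 2 already sits at the low end. On this slim basis the step of no change at the digits printed from compound 2 to compound 4 (within the scatter) is expected to stay within the scatter or run slightly lower. Compound 4 is therefore estimated at 100 mg/kg, between 30 mg/kg and 300 mg/kg.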

Compound 4, minimum effective dose: 100 mg/kg
Compound 4: middle estimate and measured number agree at the digits printed; measured number inside the range.
By their numbers in this assay, from the lowest: compounds 1, 2 and 4 (each within the scatter of the next); then compound 3.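

In this assay the change from 2-chlorophenyl to 4-fluorophenyl on the ring nitrogen gives no change at the digits printed from compound 2 to compound 4 (within the scatter), so on the core carrying the ethyl group, this part of the molecule accepts both aryl groups with no readable shift. The earlier step of a 3.0-fold higher number from compound 1 to compound 3 (0.48 log units; beyond the scatter), by contrast, came on the core without that ethyl group and involved chlorine alone, whereas the new change alters both the halogen and where it sits, and a single step cannot tell these two effects apart. Nothing available explains why the number holds steady here.

Still open, from the compounds shown here alone, is whether 4-chlorophenyl on the core of compound 2 would separate the effect of the halogen from that of its place on the ring. Going by these compounds, it is also open whether a phenyl ring with no halogen, or one bearing a methoxy group, would keep the number level.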